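From thiophen-2-yl to thiophen-3-yl on a shared core

The source may hold more compounds than are shown below. What is called first, only, known or untested is meant among the compounds shown, and "the series" means these compounds.

In a functional assay on CEM-DNR-bulk cells (Homo sapiens), read by MTT assay, with a stated time of 72 h (a higher number here means a weaker inhibitor, a lower number a stronger inhibitor), compound 1 (`Nc1nc2c(c(-c3ccoc3)cn2[C@@H]2O[C@H](CO)[C@@H](O)[C@H]2O)c(=O)[nH]1`), which carries furan-3-yl, gives 15000 nM. Compound 2 (`Nc1nc2c(c(-c3cccs3)cn2[C@@H]2O[C@H](CO)[C@@H](O)[C@H]2O)c(=O)[nH]1`), which carries thiophen-2-yl, is reported as > 20000 nM, and this is a limit of the assay, not a number. Compound 2 therefore stands at the limit of > 20000 nM in this assay, at which 1 of the 2 values shown sits.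

Compound 3 (`Nc1nc2c(c(-c3ccsc3)cn2[C@@H]2O[C@H](CO)[C@@H](O)[C@H]2O)c(=O)[nH]1`) has the same atoms as compound 2, joined differently, with thiophen-3-yl in place of thiophen-2-yl on an aromatic carbon.

For the measured compounds named here, no measured step makes this exact change. The nearest evidence is the step between the other two compounds, an at least 1.3-fold higher number from compound 1 to compound 2 (0.12 log units; that floor lies within the scatter). It also changes the group at this place, and it shows no change beyond the scatter in this assay. On that basis, no step beyond the scatter is expected, although the limit leaves the direction open. The expected step is an at least 1.2-fold lower number from compound 2 to compound 3 (0.09 log units; that floor lies within the scatter). Compound 3 could also prove to be reported only as a limit. For compound 3 the estimate is 16000 nM, with an expected range from 6000 nM to 40000 nM.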

Compound 3, half-maximal inhibitory concentration: > 20000 nM
Compound 3: a limit, no number; the forecaster's own chance of this, stated with the estimate: 45%; at least 1.2-fold (0.09 log units) between middle value and limit.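

In this assay compound 3 is reported as > 20000 nM, which is a limit of the assay and not a number. The step from thiophen-2-yl to thiophen-3-yl cannot be read, since compound 2 and compound 3 are both reported only as limits, so the change of attachment on the thiophene shows neither a gain nor a loss. The one step that can be read is an at least 1.3-fold higher number from compound 1 to compound 3 (0.12 log units; that floor lies within the scatter), which stays within the scatter, and what is new is that both thiophene attachments now end at the same reported limit, so the limit describes most of this small set: the limit of > 20000 nM in this assay, at which 2 of the 3 values shown sit.

The compounds shown leave open how far compound 2 and compound 3 lie past that limit, and so whether the attachment on the thiophene matters at all in this assay. They also leave open how this place on the shared core responds to a group of another kind, such as a phenyl ring, an amine or a carboxylic acid, and whether any such group would give a clearly lower number than compound 1 does.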